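A few compounds are considered here, and "the series" means these few. Any claim that something is new, unique, unknown or untested is made for them only; others in the source may bear on it.

Working notes on the series. In an ADME assay on MT4 cells (Homo sapiens) for cytotoxicity, read by MTT assay, with a stated time of 4 days (on this read-out higher numbers stand for lower toxicity in this test and lower numbers for higher toxicity in this test), compound 1 (`Nc1ccc2oc(-c3ccc(F)cc3)cc(=O)c2c1`) gives 264000 nM and compound 2 (`Nc1ccc2oc(-c3cccc(C(F)(F)F)c3)cc(=O)c2c1`) gives 138000 nM while compound 3 (`Nc1ccc2oc(-c3ccc(C(F)(F)F)cc3)cc(=O)c2c1`) gives 273000 nM as its reading, so compound 3 stands level with both others within the scatter. Compound 4 (`Nc1ccc2oc(-c3ccc(C(F)(F)F)cc3)c(O)c(=O)c2c1`) differs from compound 3 by hydroxy in place of hydrogen on an aromatic carbon and this carbon belongs to the six-membered aromatic ring with 1 oxygen. For the measured compounds named here, the only measured single-site step is a 1.0-fold higher number from compound 1 to compound 3 (0.01 log units; within the scatter) and it is a swap of trifluoromethyl for fluoro, so it bears on the new change only weakly. Going by the values given here, no measured step covers hydroxy on this carbon and the data give no firm direction. The flat values suggest no step beyond the scatter in this assay but with low confidence. The estimated move is a 1.8-fold lower number from compound 3 to compound 4 (0.26 log units; within the scatter) on this reasoning. Compound 4 is expected at 150000 nM with an estimated range from 40000 nM to 320000 nM in this test.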

Compound 4, half-maximal cytotoxic concentration: 3900 nM
The estimate for compound 4 lay 38-fold (1.59 log units) above the measured number, outside the stated range (below it).
By their numbers in this assay, from the lowest: compound 4; then compounds 2, 1 and 3 (each within the scatter of the next).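

In this assay, for the compounds shown here, hydroxy in place of hydrogen on an aromatic carbon of the six-membered aromatic ring with 1 oxygen gives a 70-fold lower number from compound 3 to compound 4 (1.85 log units; beyond the scatter), the only step beyond the scatter so far. Compounds 1, 2 and 3 vary only in fluoro or trifluoromethyl on the aromatic ring outside the shared core and leave this carbon unsubstituted, so they gave no sign that the read-out could respond so strongly to a change here. Lower toxicity in this test is therefore not retained once this carbon carries hydroxy, at least with the trifluoromethyl group of compound 3 in place. Nothing in the data on hand speaks to the origin of this step. Going by these compounds, whether a methoxy group or an amine on the same carbon would produce a similar drop remains open. Also open, on these data alone, is whether hydroxy here has a step of similar size on the fluoro analogue, compound 1.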